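Methyl for bromo on the amide-side aryl ring

The source may report more compounds than this note shows. Statements on the series, on what has been measured and on what is new or still open speak of the compounds shown alone.

Compound 1 `COc1ccc(-c2cnc(NC(=O)c3cccc(Br)c3)n2C)cc1` stands at a limit in a toxicity assay on THP-1 cells (Homo sapiens) for inhibition; a lower number here means that less compound is tolerated, a higher number that more compound is tolerated: in this assay compound 1 gives > 100000 nM, which is a limit of the assay and not a number. Compound 3 `Cn1c(-c2ccccc2)cnc1NC(=O)c1cccc(Br)c1` likewise gives a limit in this assay, > 50000 nM. Compound 2 `Cn1c(-c2ccc(Br)cc2)cnc1NC(=O)c1ccc(F)cc1` gives 46000 nM in this assay. The step that the two limits leave unreadable from compound 1 to compound 3 cannot be sized, and the two limits the limit of > 100000 nM in this assay, at which 1 of the 3 values shown sits, and the limit of > 50000 nM in this assay, at which 1 of the 3 values shown sits, are all that surrounds compound 1. Compound 4 `COc1ccc(-c2cnc(NC(=O)c3cccc(C)c3)n2C)cc1` differs from compound 1 thus: methyl in place of bromo on an aromatic carbon. Among the measured compounds shown here, no measured step bears on this change, so no shift beyond the scatter is expected. Compound 4 is expected at 100000 nM, between 40000 nM and 250000 nM. The expected step is a number no higher from compound 1 to compound 4 (the limit leaves the size open), most likely reported again as a limit.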

Compound 4, half-maximal cytotoxic concentration: > 100000 nM
Compound 4 ended at the assay's limit (the forecaster's own chance of this, stated with the estimate: 70%); the middle value lies on the limit itself.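

Among the compounds shown here, compound 1 and compound 4 both stand at a limit in this assay, so no step between them can be read. Going by these compounds, whether 3-bromophenyl to 3-methylphenyl moves the half-maximal cytotoxic concentration at all remains open.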